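This account rests on a few compounds, and the source may have more. Where it says the series, first, only, none or still open, it means among the compounds named here.

Measured compounds:
Compound 1 `COc1cc2c(Oc3ccc(NC(=O)N/N=C/c4ccc([N+](=O)[O-])cc4)cc3F)ccnc2cc1OCCCN1CCCC1`; in a functional assay on HT-29 cells (Homo sapiens) for cytotoxicity, read by MTT assay, with a stated time of 72 h (a higher number here means a weaker inhibitor, a lower number a stronger inhibitor), compound 1 gives 310 nM.
Compound 2 `COc1cc2c(Oc3ccc(NC(=O)N/N=C/c4ccc(C(F)(F)F)cc4)cc3F)ccnc2cc1OCCCN1CCCCC1`; in this assay compound 2 gives 660 nM.
Compound 3 `COc1cc2c(Oc3ccc(NC(=O)N/N=C/c4ccc(OC(F)(F)F)cc4)cc3F)ccnc2cc1OCCCN1CCCCC1`; in this assay compound 3 gives 510 nM.

Compound 3 holds the second highest of the three numbers. Its nearest neighbour is compound 2: the step of a 1.3-fold lower number from compound 2 to compound 3 (0.11 log units; within the scatter) is within the scatter. The furthest is compound 1, whose number 310 nM sits below that of compound 3 by a gap that also lies within the scatter, so the three measured compounds are not separated from one another.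

Compound 4 `C=CCc1cccc(/C=N/NC(=O)Nc2ccc(Oc3ccnc4cc(OCCCN5CCCCC5)c(OC)cc34)c(F)c2)c1OC` is not yet measured. It differs from compound 3 by 3-allyl-2-methoxyphenyl in place of 4-(trifluoromethoxy)phenyl on a carbon with a double bond to nitrogen. Among the compounds with values here, the only measured step that touches this position is the step from compound 2 to compound 3, an exchange of one substituent on the same ring, and it stayed within the scatter. Within the data shown here, no measured step exchanges the whole ring for one carrying a different set of groups, so the bearing of the series on this change is weak. The step of a 1.2-fold higher number from compound 3 to compound 4 (0.07 log units; within the scatter) is therefore expected to be small, with no direction that rises above the scatter. For compound 4 in this assay the estimate is 600 nM, with a range from 250 nM to 1500 nM.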

Compound 4, half-maximal inhibitory concentration: 460 nM
Compound 4: the middle estimate sits 1.3-fold (0.12 log units) above what was measured; measured number inside the range.
By their numbers in this assay, from the lowest: compounds 1, 4, 3 and 2 (each within the scatter of the next, the first and the last beyond it).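

Replacing the whole aryl group on a carbon with a double bond to nitrogen, rather than one substituent on it, leaves the number in this assay within the scatter: a 1.1-fold lower number from compound 3 to compound 4 (0.04 log units; within the scatter), and a 1.4-fold lower number from compound 2 to compound 4 (0.16 log units; within the scatter). The earlier step exchanged only trifluoromethoxy for trifluoromethyl, whereas 3-allyl-2-methoxyphenyl has no fluorine and brings a double bond outside aromatic rings, so across compound 2, compound 3 and compound 4 the position accepts a much larger change of substituents without a separation in this read-out. Nothing available here explains why these aryl groups are not separated.

Still open, from the compounds shown here alone, is whether an aryl group carrying an amine or a carboxylic acid, or a saturated cyclohexyl ring in its place, would shift the number beyond the scatter. Compound 1 differs from compound 4 in more than one place, so the contribution of its amine ring cannot be separated from that of its aryl group.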